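A Second Hydroxy on a Level Series

The compounds below may be only part of what the source reports. "The series", "measured", "known", "first", "only" and "open" are said of these compounds alone.

In a functional assay on KB cells (Homo sapiens) for cytotoxicity, read by sulforhodamine B assay, with a stated time of 72 h (on this read-out higher numbers stand for an effect only at larger amounts of compound and lower numbers for an effect already at smaller amounts), compound 1 `Cc1cccc(-c2cc3occ(C)c3c(=O)o2)c1` gives 43.8 uM and compound 2 `CCOc1cccc(-c2cc3occ(C)c3c(=O)o2)c1` gives 64.4 uM while compound 3 `Cc1coc2cc(-c3cccc(O)c3)oc(=O)c12` gives 65.3 uM so compound 3 stands level with both, within the usual scatter. Compound 4 `Cc1coc2cc(-c3ccc(O)c(O)c3)oc(=O)c12` differs from compound 3 by hydroxy in place of hydrogen on an aromatic carbon with hydroxy in place of hydrogen on an aromatic carbon, ortho to a hydroxy group and para to a large group. For the measured compounds named here, no measured step adds a second hydroxy. The nearest guides are a 1.5-fold higher number from compound 1 to compound 3 (0.17 log units; within the scatter) and a 1.0-fold higher number from compound 2 to compound 3 (0.01 log units; within the scatter) along with a 1.5-fold higher number from compound 1 to compound 2 (0.17 log units; within the scatter) and each lies within the scatter. No shift beyond the scatter is therefore expected in this assay and the expected move is a 1.3-fold lower number from compound 3 to compound 4 (0.12 log units; within the scatter) at most a small one. Compound 4 is estimated at 50 uM with an expected range from 22 uM to 110 uM around that middle.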

Compound 4, concentration for half-maximal effect: 20.2 uM
Estimate against measurement, compound 4: 2.5-fold (0.39 log units) above; the whole stated range lies above it.
By their numbers in this assay, from the lowest: compound 4; then compounds 1, 2 and 3 (each within the scatter of the next).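

Hydroxy in place of hydrogen, ortho to a hydroxy group and para to a large group, gives a 3.2-fold lower number from compound 3 to compound 4 (0.51 log units; beyond the scatter) in this assay, the only step shown that lies beyond the scatter. This place on the ring therefore responds to a change, whereas the swaps among methyl, ethoxy and hydroxy linking compound 1, compound 2 and compound 3 all stay within the scatter. No measurement shown gives a reason for this step.

From the compounds shown here alone, it remains open whether the step depends on the hydroxy already present in compound 3. Going by these compounds, it is also open whether an amine or a carboxylic acid at this place would give a similar step.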